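The source may report more compounds than this note shows. Statements on the series, on what has been measured and on what is new or still open speak of the compounds shown alone.

In a functional assay on SW480 cells (Homo sapiens) for antiproliferative activity, read by MTT assay, with a stated time of 48 h (on this read-out lower numbers stand for stronger inhibition and higher numbers for weaker inhibition), three compounds sharing one core have been measured. Compound 1 `CC(C)=CCC[C@]1(C)/C=C/[C@@H](OC(=O)C=C(C)C)[C@](C)(O)/C=C/C(=O)/C(C(=O)O)=C\C1`, which carries carboxy on a double-bonded ring carbon, reads > 10000 nM, and this is a limit of the assay rather than a number. Compound 2 `COCOC/C1=C/C[C@](C)(CCC=C(C)C)/C=C/[C@@H](OC(=O)C=C(C)C)[C@](C)(O)/C=C/C1=O` gives 3710 nM. Compound 3 `CC(C)=CCC[C@]1(C)/C=C/[C@@H](OC(=O)C=C(C)C)[C@](C)(O)/C=C/C(=O)/C(Cn2cc(CO)nn2)=C\C1` gives 2870 nM, which makes it the lowest of the two true numbers, yet the gap is only a 1.3-fold lower number from compound 2 to compound 3 (0.11 log units; within the scatter).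

Compound 4 `CCN(CC)C(=O)/C1=C/C[C@](C)(CCC=C(C)C)/C=C/[C@@H](OC(=O)C=C(C)C)[C@](C)(O)/C=C/C1=O` has diethylcarbamoyl in place of (4-(hydroxymethyl)-1H-1,2,3-triazol-1-yl)methyl on a double-bonded ring carbon. Two measured steps replace carboxy at this ring carbon: an at least 2.6-fold lower number from compound 1 to compound 2 (0.43 log units; beyond the scatter) and an at least 3.4-fold lower number from compound 1 to compound 3 (0.54 log units; beyond the scatter). Compound 4 also lacks carboxy, so it should resemble compound 2 and compound 3 more than compound 1, although two examples are thin support. No step beyond the scatter is therefore expected, and the estimated step is a 1.4-fold higher number from compound 3 to compound 4 (0.14 log units; within the scatter). The expected value for compound 4 is 4000 nM, with an estimated range of 1300 nM to 10000 nM.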

Compound 4, half-maximal inhibitory concentration: 11700 nM
Estimate against measurement, compound 4: 2.9-fold (0.47 log units) below, and the stated range ends below it.
By their numbers in this assay, from the lowest: compounds 3 and 2 (each within the scatter of the next); then compound 4.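

Diethylcarbamoyl shows that this ring carbon does respond to the group placed on it, since it gives a 4.1-fold higher number from compound 3 to compound 4 (0.61 log units; beyond the scatter) and a 3.2-fold higher number from compound 2 to compound 4 (0.50 log units; beyond the scatter), whereas the exchange between the two earlier groups stayed within the scatter, at a 1.3-fold lower number from compound 2 to compound 3 (0.11 log units; within the scatter). Removing carboxy is therefore not enough on its own to give the lower numbers: compounds 2 and 3 hold their groups through a saturated chain carbon, while compound 4, like compound 1, has a carbonyl carbon there. Compound 1 has only a limit, so its step to compound 4 cannot be read: the limit of > 10000 nM in this assay, at which 1 of the 4 values shown sits.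

Whether the carbonyl carbon or the diethylamino part accounts for the higher number in compound 4 remains open. A diethylaminomethyl group, with the same amine on a saturated chain carbon, would separate the two.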